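Swapping the aryl group on the aminoquinazoline-type nitrogen

A few compounds are considered here, and "the series" means these few. Any claim that something is new, unique, unknown or untested is made for them only; others in the source may bear on it.

The measured compounds, all in a functional assay on PC-3 cells (Homo sapiens) for inhibition, read by MTT assay, with a stated time of 72 h; a higher number here means a weaker inhibitor, a lower number a stronger inhibitor:
compound 1 `CCc1ccc(NC(=O)CSc2nc(Nc3ccccc3)c3ccccc3n2)cc1` gives 17900 nM
compound 2 `O=C(CSc1nc(Nc2ccccc2)c2ccccc2n1)Nc1ccc(Cl)c(Cl)c1` gives 12100 nM
compound 3 `C=CC(=O)Nc1cccc(NC(=O)CSc2nc(Nc3ccccc3Cl)c3ccccc3n2)c1` gives 14400 nM

Compound 3 stands second highest of the three numbers; its nearest neighbour is compound 2, at a slightly lower number, and its furthest is compound 1, at a slightly higher number, both gaps within the scatter. The three values therefore sit in one narrow band.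

Compound 4 `C=CC(=O)Nc1cccc(NC(=O)CSc2nc(Nc3ccc(C(F)(F)F)cc3)c3ccccc3n2)c1` differs from compound 3 in one place: 4-(trifluoromethyl)phenyl in place of 2-chlorophenyl on a nitrogen on an aromatic ring. Among the compounds with values here, the only measured step, a 1.5-fold lower number from compound 1 to compound 2 (0.17 log units; within the scatter), concerns the group on an amide-type nitrogen, a different place, and was itself within the scatter. Within the data shown here, no step among the measured compounds bears on a change at a nitrogen on an aromatic ring, so the data offer no direction for this change. Given how closely compounds 1, 2 and 3 agree in this assay, compound 4 is expected to stay in the same band, with a step of about a 1.0-fold lower number from compound 3 to compound 4 (0.01 log units; within the scatter). Compound 4 is estimated at 14000 nM, with a range from 6000 nM to 33000 nM.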

Compound 4, half-maximal inhibitory concentration: 12500 nM
Compound 4: the middle estimate sits 1.1-fold (0.05 log units) above what was measured; the range from low to high includes it.
By their numbers in this assay, from the lowest: compounds 2, 4, 3 and 1 (each within the scatter of the next).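

In this assay, within the data shown here, 4-(trifluoromethyl)phenyl in place of 2-chlorophenyl on a nitrogen on an aromatic ring gives a 1.2-fold lower number from compound 3 to compound 4 (0.06 log units; within the scatter), the first reading of a change at this position. Two differently substituted phenyl groups are therefore tolerated here without the number leaving the narrow band set by compounds 1, 2 and 3, so this exchange does not separate compound 3 from compound 4. Nothing given here accounts for this result.

Because the chloro and trifluoromethyl groups also carry different ring numbers in their names, this single step cannot show whether the identity of the group or its place on the phenyl ring matters. On these data alone, it also remains open whether the number would move with a phenyl ring bearing an amine or a carboxylic acid, or with a simple alkyl chain on this nitrogen.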